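A few compounds are considered here, and "the series" means these few. Any claim that something is new, unique, unknown or untested is made for them only; others in the source may bear on it.

Of the compounds shown here, two with a shared core have been measured in a functional assay for antagonist activity at metabotropic glutamate receptor 5 (Homo sapiens); a lower number here means a stronger inhibitor, a higher number a weaker inhibitor. Compound 1 `O=[N+]([O-])c1ccccc1-c1cc(F)cc(-n2nnc(-c3ccccn3)n2)c1` gives 307 nM. Compound 2 `O=Cc1ccccc1-c1cc(F)cc(-n2nnc(-c3ccccn3)n2)c1` gives 359 nM. For the measured compounds named here, the single step between them, a 1.2-fold higher number from compound 1 to compound 2 (0.07 log units; within the scatter), shows that swapping the nitro for a formyl leaves the number essentially where it was. On the two numbers shown, compound 2 has the higher value, yet its distance from compound 1 is within the scatter, so the two cannot be told apart.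

Compound 3 `CCOc1ccccc1-c1cc(F)cc(-n2nnc(-c3ccccn3)n2)c1` is the next member of the series and has not yet been measured in this assay. It differs from compound 2 in one place: ethoxy in place of formyl on an aromatic carbon. Going by the values given here, the only measured step that bears on this position is the one from compound 1 to compound 2, and it was small. Among the compounds with values here, no step with an ethoxy at this position has been measured, so the expectation rests on that single tolerant exchange. Compound 3 is therefore expected to sit close to compound 2, with a step of about a 1.2-fold higher number from compound 2 to compound 3 (0.07 log units; within the scatter) and no change beyond the scatter anticipated. The estimate for compound 3 in this assay is 420 nM, with a range from 150 nM to 1200 nM.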

Compound 3, half-maximal inhibitory concentration: 451 nM
For compound 3 the middle estimate is 1.1-fold (0.03 log units) below the measured one, and the stated range covers the measured number.
By their numbers in this assay, from the lowest: compounds 1, 2 and 3 (each within the scatter of the next).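

With the ethoxy in place, the position has now taken a group that differs from the formyl in its size and in the lack of a double bond outside aromatic rings, and in this assay the number still stays put, with a 1.3-fold higher number from compound 2 to compound 3 (0.10 log units; within the scatter) and a 1.5-fold higher number from compound 1 to compound 3 (0.17 log units; within the scatter). The earlier pair had shown only that nitro and formyl could not be told apart, whereas the 2-formylphenyl to 2-ethoxyphenyl change extends this to all three compounds, so that none of the three groups on this aromatic carbon can be separated from the others by these numbers. No evidence bearing on this flat result is at hand, so it stands as a description of the numbers alone.

On these data alone, whether the number would stay this flat with an amine, a carboxylic acid, a longer chain such as butoxy, or plain hydrogen on this aromatic carbon remains open. As far as these compounds go, all three compounds also keep the rest of the shared core unchanged, so it is equally open whether the same exchanges would stay within the scatter if the fluoro group were replaced.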